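Methyl for bromo on the core, beside a limit

This account rests on a few compounds, and the source may have more. Where it says the series, first, only, none or still open, it means among the compounds named here.

Three analogues of one oxindole-derived thiosemicarbazone core have numbers in a functional assay on HeLa cells (Homo sapiens) for inhibition, read by MTT assay; a lower number here means a stronger inhibitor, a higher number a weaker inhibitor. Compound 1 `O=C1Nc2ccc(Br)cc2/C1=N/NC(=S)N/N=C/c1c(F)cccc1Cl` gives 1610 nM. Compound 2 `O=C1Nc2ccc(Br)cc2/C1=N/NC(=S)N/N=C/c1c(Cl)cccc1Cl` gives 3530 nM, and the change is a 2.2-fold higher number from compound 1 to compound 2 (0.34 log units; beyond the scatter). Compound 3 `O=C1Nc2ccc(Br)cc2/C1=N/NC(=S)N/N=C/c1ccccc1Br` gives only a limit, > 50000 nM, which is the limit of this assay, (the limit of > 50000 nM in this assay, at which 1 of the 3 values shown sits). Compound 3 therefore stands at the weak end of the three: the steps are an at least 31-fold higher number from compound 1 to compound 3 (1.49 log units; beyond the scatter) and an at least 14-fold higher number from compound 2 to compound 3 (1.15 log units; beyond the scatter).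

Compound 4 `Cc1ccc2c(c1)/C(=N/NC(=S)N/N=C/c1ccccc1Br)C(=O)N2` differs from compound 3 by methyl in place of bromo on an aromatic carbon. Among the measured compounds shown here, none of the measured steps touches this position; all three concern the other aryl ring, so no measured step bears directly on the change from compound 3 to compound 4. With compound 3 already at the limit, the step is expected to be a step that the limit leaves unreadable from compound 3 to compound 4, meaning no clear movement beyond the scatter in this assay. Compound 4 is thus expected to give about 60000 nM, within a range from 20000 nM to 200000 nM, most likely again only as a limit.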

Compound 4, half-maximal inhibitory concentration: > 50000 nM
Compound 4 was reported as a limit (the forecaster's own chance of this, stated with the estimate: 70%); the middle value is on the limit's open side.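

Compound 3 and compound 4 both stand at a limit in this assay, so the step between them cannot be read: the limit of > 50000 nM in this assay, at which 2 of the 4 values shown sit.

The compounds shown leave open what methyl in place of bromo does where the other aryl group is 2-chloro-6-fluorophenyl or 2,6-dichlorophenyl, as in compound 1 and compound 2, whose values are not limits.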